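The source may hold more compounds than are shown below. What is called first, only, known or untested is meant among the compounds shown, and "the series" means these compounds.

Measured in a functional assay on MCF7 cells (Homo sapiens) for cytotoxicity, read by sulforhodamine B assay, with a stated time of 48 h; a lower number here means a stronger inhibitor of growth, a higher number a weaker inhibitor of growth:
- compound 1 `Cc1ccc(-c2ccc(F)cc2)n1-c1ccc(-c2nc3ccccc3s2)cc1` gives 2620 nM
- compound 2 `Cc1ccc(-c2ccc(F)cc2)n1-c1ccc(-c2nc3ccc(F)cc3s2)cc1` gives 1790 nM
- compound 3 `COc1ccc(-c2ccc(C)n2-c2ccc(-c3nc4ccc(F)cc4s3)cc2)cc1` gives 2120 nM

On these numbers compound 2 carries the lowest value of the three, yet its gaps to compound 3 and to compound 1 both fall within the scatter, so the three cannot be told apart. Compound 4 `COc1ccc2nc(-c3ccc(-n4c(C)ccc4-c4ccc(F)cc4)cc3)sc2c1` differs from compound 2 by methoxy in place of fluoro on an aromatic carbon. Within the data shown here, two measured steps bear on this change: a 1.5-fold lower number from compound 1 to compound 2 (0.17 log units; within the scatter) at the same place, and a 1.2-fold higher number from compound 2 to compound 3 (0.07 log units; within the scatter), the same exchange at another place. Both stayed within the scatter, so no step beyond the scatter is expected in this assay for compound 4. Compound 4 is therefore estimated at 2000 nM, within 900 nM to 4500 nM, a step of a 1.1-fold higher number from compound 2 to compound 4 (0.05 log units; within the scatter).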

Compound 4, concentration for 50% growth inhibition: 2480 nM
For compound 4 the middle estimate is 1.2-fold (0.09 log units) below the measured one; low and high end bracket the measured number.
By their numbers in this assay, from the lowest: compounds 2, 3, 4 and 1 (each within the scatter of the next).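

In this assay this place on the fused ring system now has three occupants: hydrogen in compound 1, fluoro in compound 2 and methoxy in compound 4. Methoxy in place of fluoro gives a 1.4-fold higher number from compound 2 to compound 4 (0.14 log units; within the scatter) and methoxy in place of hydrogen gives a 1.1-fold lower number from compound 1 to compound 4 (0.02 log units; within the scatter) so neither exchange at this place moves the number beyond the scatter. No measurement at hand offers an explanation. From the compounds shown here alone, whether an amine or a carboxylic acid at this place would move the number beyond the scatter remains open.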